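The source may report more compounds than this note shows. Statements on the series, on what has been measured and on what is new or still open speak of the compounds shown alone.

Measured compounds:
Compound 1, `CC1(C)OC(Nc2ccccc2)=C(C(=O)O)C1=O`, gives 44% in a functional assay on the whole organism for inhibition, with Rattus norvegicus as the target, at a dose of 100 mg/kg by the intraperitoneal route; a lower number here means less inhibition, a higher number more inhibition at the dose given (going by the name of the read-out).
Compound 2, `O=C(O)C1=C(Nc2cccc3ccccc23)OCC1=O`, gives 64% in this assay.

Compound 1 stands lowest of the two numbers in this assay. Its nearest neighbour is compound 2, whose value lies higher by a margin beyond the usual scatter of repeated measurements. The two measured compounds differ at several places at once, so their gap cannot be tied to any single change.

Compound 3, `CC1OC(Nc2ccccc2)=C(C(=O)O)C1=O`, has not yet been measured in this assay. It differs from compound 1 in one place: hydrogen in place of methyl on a saturated ring carbon. For the measured compounds named here, no pair of measured compounds separated by this change alone is available, so nothing measured speaks directly to its effect. Resting only on the value of compound 1, the step from compound 1 to compound 3 in this assay is expected to be a number 1 percentage points higher from compound 1 to compound 3 (within the scatter), that is, none beyond the scatter. For compound 3, the value expected in this assay is 45%, with a range from 25% to 65%.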

Compound 3, a percentage reported as inhibition, in the whole organism at one dose (the size of the read-out at that dose, not a potency): 60%
Beside the measured number, compound 3's estimate is 15 percentage points below it; measured number inside the range.
By their numbers in this assay, from the lowest: compound 1; then compounds 3 and 2 (each within the scatter of the next).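

In this assay, for the compounds shown here, this is the first change that can be read on its own, and it shows that the saturated ring carbon next to the ring oxygen is sensitive to what it carries: hydrogen in place of methyl there gives a number 16 percentage points higher from compound 1 to compound 3 (beyond the scatter), a modest step but one that can be told apart from scatter. Compound 3 still carries a methyl on that carbon, so the step comes from taking away just one of the pair of methyl groups in compound 1, with the rest of the structure unchanged. Nothing available bears on why the number moves with this change.

This single pair cannot show whether the trend continues, since the compounds shown leave open what hydrogen in place of the remaining methyl of compound 3 would give on the same core. They also leave open how an ethyl group, a longer chain or a hydroxymethyl group on this ring carbon would fare, and so whether the step depends on the size of the group or only on the methyl.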